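The source may hold more compounds than are shown below. What is called first, only, known or untested is meant among the compounds shown, and "the series" means these compounds.

Compound 1 `Cc1nnc(SCC(=O)c2ccc(Cl)cc2)n1N1C(=O)c2ccccc2C1=O`: > 200000 nM
Compound 2 `C=CCSc1nnc(-c2cc(OC)c(OC)c(OC)c2)n1N1C(=O)c2ccccc2C1=O`: > 200000 nM

In a functional assay on MKN-45 cells (Homo sapiens) for cytotoxicity, read by MTT assay, with a stated time of 48 h (on this read-out higher numbers stand for weaker inhibition and lower numbers for stronger inhibition), compound 1 gives > 200000 nM, which is a limit of the assay rather than a number. Compound 2 gives > 200000 nM in this assay, again only a limit. Both values shown sit at the same point, (the limit of > 200000 nM in this assay, at which 2 of the 2 values shown sit), so compound 2 stands nowhere that a number could place it. Compound 3 `COc1cc(-c2nnc(SCC(=O)c3ccc(Br)cc3)n2N2C(=O)c3ccccc3C2=O)cc(OC)c1OC` differs from compound 2 by (4-bromophenyl)carbonyl in place of vinyl on a saturated chain carbon bound to a sulfur. Within the data shown here, no step between measured compounds is known here. The change is expected to be an at least 1.3-fold lower number from compound 2 to compound 3 (0.12 log units; that floor lies within the scatter), that is, nothing clearly beyond the scatter. Compound 3 is estimated at 150000 nM, between 30000 nM and 600000 nM.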

Compound 3, half-maximal inhibitory concentration: 22300 nM
Beside the measured number, compound 3's estimate is 6.7-fold (0.83 log units) above it; measured number outside the range, below it.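

In this assay, replacing vinyl with (4-bromophenyl)carbonyl on the saturated chain carbon bound to a sulfur gives an at least 8.9-fold lower number from compound 2 to compound 3 (0.95 log units; beyond the scatter), the first sign that this position can change the read-out. Going by these compounds, compound 2 gives > 200000 nM, a limit and not a number, so the step's full size stays unknown. Compound 3 is the only compound shown to give a number rather than a limit: the limit of > 200000 nM in this assay, at which 2 of the 3 values shown sit.

Still open, on these data alone, is whether the bromine, the carbonyl or the aromatic ring accounts for the step. Also open, as far as these compounds go, is how an amine or a carboxylic acid at this position would read.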